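The compounds below may be only part of what the source reports. "The series", "measured", "known", "first", "only" and "open" are said of these compounds alone.

Compound 1 `Cc1c(C)c2ccc(OCC3CCN(Cc4ccc(CO)cc4)CC3)cc2oc1=O` stands lowest of the two measured compounds: in an assay for inhibition of Amine oxidase [flavin-containing] A (Homo sapiens), read by fluorescence, using microsomes, with a stated time of 30 min (a lower number here means a stronger inhibitor, a higher number a weaker inhibitor), compound 1 gives 1400 nM, while compound 2 `Cc1cc(=O)oc2cc(OCC3CCN(Cc4ccc(CO)cc4)CC3)ccc12` gives 11000 nM. Going by the values given here, the only measured step, a 7.9-fold higher number from compound 1 to compound 2 (0.90 log units; beyond the scatter), concerns a methyl on the shared core, not the group on the saturated chain carbon bound to the amine nitrogen. Compound 3 `Cc1c(C)c2ccc(OCC3CCN(Cc4cccc(OCCCO)c4)CC3)cc2oc1=O` differs from compound 1 by 3-(3-hydroxypropoxy)phenyl in place of 4-(hydroxymethyl)phenyl on a saturated chain carbon bound to an amine nitrogen in a ring. Among the compounds with values here, no measured step bears on this change, so the expected step of a 1.1-fold higher number from compound 1 to compound 3 (0.03 log units; within the scatter) is small, in no clear direction. Compound 3 is therefore estimated at 1500 nM, within a range from 400 nM to 6000 nM.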

Compound 3, half-maximal inhibitory concentration: 550 nM
Compound 3: the middle estimate sits 2.7-fold (0.44 log units) above what was measured; low and high end bracket the measured number.
By their numbers in this assay, from the lowest: compound 3; then compound 1; then compound 2.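

Moving from 4-(hydroxymethyl)phenyl to 3-(3-hydroxypropoxy)phenyl on the saturated chain carbon bound to an amine nitrogen in a ring gives a 2.5-fold lower number from compound 1 to compound 3 (0.41 log units; beyond the scatter) in this assay and so yields a stronger inhibitor. This place therefore accepts a group with more heavy atoms and an added hydrogen-bond acceptor without any loss of inhibition. Nothing available explains this gain.

The change alters both the ring attachment and the chain, so the two effects cannot be separated. Going by these compounds, whether an amine or a carboxylic acid could replace the end hydroxyl remains open.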